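This account rests on a few compounds, and the source may have more. Where it says the series, first, only, none or still open, it means among the compounds named here.

In an ADME assay on HEK293 cells (Homo sapiens) for cytotoxicity, read by resazurin assay, with a stated time of 72 h (a higher number here means that more compound is tolerated, a lower number that less compound is tolerated), compound 3 (`O=C(O)c1ccc(CCOc2c(F)ccc3nc(C(=O)NCC4CCCCC4)[nH]c(=O)c23)cc1`) stands at > 20000 nM as a limit of the assay and not a number. Compound 1 (`COc1cccc(CNC(=O)c2nc3ccc(F)c(OCCc4ccccc4)c3c(=O)[nH]2)c1`) shows > 20000 nM as a limit too. Compound 2 (`O=C(O)c1ccc(CCOc2c(F)ccc3nc(C(=O)NCc4ccccc4)[nH]c(=O)c23)cc1`) shows > 20000 nM as a limit too. All three share one reading (the limit of > 20000 nM in this assay, at which 3 of the 3 values shown sit) and no actual number is in hand.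

Compound 4 (`COc1cc(CNC(=O)c2nc3ccc(F)c(OCCc4ccc(C(=O)O)cc4)c3c(=O)[nH]2)ccc1F`) changes one group (4-fluoro-3-methoxyphenyl in place of cyclohexyl on a saturated chain carbon bound to an amide-type nitrogen) so that 4-fluoro-3-methoxyphenyl stands in place of cyclohexyl on a saturated chain carbon bound to an amide-type nitrogen. For the measured compounds named here, the only measured step at that place is a step that the two limits leave unreadable from compound 2 to compound 3 with cyclohexyl in place of phenyl. Every reading sits at the same limit, so no step beyond the usual scatter is expected in this assay in either direction. The expected step is a number no higher from compound 3 to compound 4 (the limit leaves the size open) on this reasoning. For compound 4 the estimate is 20000 nM with an expected range from 10000 nM to 40000 nM and another limit is the likeliest report.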

Compound 4, half-maximal cytotoxic concentration: > 20000 nM
Compound 4: a limit, no number; the forecaster's own chance of this, stated with the estimate: 85%; the middle value lies on the limit itself.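

Compound 4 gives a limit of the assay and not a number, so its steps from compound 2 and compound 3 cannot be read. All the compounds shown share one reading: the limit of > 20000 nM in this assay, at which 4 of the 4 values shown sit. What stays open is the actual concentration at which any of these compounds harms the cells, and whether phenyl, cyclohexyl or 4-fluoro-3-methoxyphenyl changes it.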